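The source may hold more compounds than are shown below. What is called first, only, known or untested is meant among the compounds shown, and "the series" means these compounds.

Measured so far:
compound 1 `CCOc1ccc2c(=O)c(-c3ccc(O)cc3)coc2c1` — 95.6%
compound 2 `O=c1c(-c2ccc(O)cc2)coc2cc(CC3OC(CO)C(O)C(O)C3O)ccc12` — 0%
compound 3 `O=c1c(-c2ccc(O)cc2)coc2cc(OCCCCCCBr)ccc12` — 88.5%

In a functional assay on mitochondria (Cricetulus griseus) for inhibition of Monoamine oxidase (Homo sapiens), tested at 3 uM (on this read-out lower numbers stand for a weaker effect and higher numbers for a stronger effect at the one concentration tested), compound 3 stands second highest of the three numbers. Its nearest neighbour is compound 1, and the step of a number 7.1 percentage points lower from compound 1 to compound 3 (within the scatter) lies within the scatter, so the two cannot be ordered. Among the measured compounds shown here, its furthest neighbour is compound 2, for which compound 2 gives 0% against the value of compound 3, a gap beyond the scatter; no single-place step links compound 2 to compound 3.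

Compound 4 `O=c1c(-c2ccc(O)cc2)coc2cc(OCCC3OCCCO3)ccc12` has not yet been measured. It differs from compound 3 in one place: a group of 6 heavy atoms (4 carbon, 2 oxygen; one six-membered non-aromatic ring with 2 hetero atoms) in place of a group of 5 heavy atoms (4 carbon, 1 bromine; no ring), on a saturated chain carbon, two bonds along the chain from an oxygen on an aromatic ring

For the measured compounds named here, only one measured step bears on this place, a number 7.1 percentage points lower from compound 1 to compound 3 (within the scatter), which shows that filling this place with a 4-bromobutyl group moves the read-out by an amount within the scatter. Going by the values given here, no measured step tells what a group with a six-membered non-aromatic ring and two hydrogen-bond acceptors does at this place. Among the compounds with values here, compound 2, the one measured compound whose substituent carries a ring and several oxygens, gives 0%, but it differs from compound 3 in more than one place, so it gives only a loose caution. The expected step from compound 3 to compound 4 in this assay is therefore a modest lowering, a number 16.5 percentage points lower from compound 3 to compound 4 (beyond the scatter), with a wide range to allow for the untested ring. Compound 4 is expected to give 72%, between 35% and 95%.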

Compound 4, a percentage reported as inhibition, at one concentration (the size of the read-out at that concentration, not a potency): 75.3%
For compound 4 the middle estimate is 3.3 percentage points below the measured one; the range from low to high includes it.
By their numbers in this assay, from the lowest: compound 2; then compound 4; then compounds 3 and 1 (each within the scatter of the next).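

In this assay, this position is no longer silent: the change at the saturated chain carbon, two bonds along the chain from an oxygen on an aromatic ring, gives a number 13.2 percentage points lower from compound 3 to compound 4 (beyond the scatter), and measured against the hydrogen of compound 1 it gives a number 20.3 percentage points lower from compound 1 to compound 4 (beyond the scatter). Both steps are modest, so a six-membered non-aromatic ring with 2 hetero atoms and 2 hydrogen-bond acceptors is accommodated at this place with a measurable loss, and the read-out of compound 4 remains at 75.3%, whereas 4-bromobutyl had produced no step beyond the scatter. No evidence is available that explains this lowering.

The step from compound 3 to compound 4 exchanges an open chain with a bromine for a ring with two oxygens, so the compounds shown leave open whether the ring or its oxygens accounts for the lowering, a question that an open-chain diether or a plain cyclohexyl group at this place could separate. From the compounds shown here alone, how an amine or a carboxylic acid at the same place would read also remains open, as does whether these single-concentration differences would carry over to potency.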